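A few compounds are considered here, and "the series" means these few. Any claim that something is new, unique, unknown or untested is made for them only; others in the source may bear on it.

Measured in an ADME assay (liver, Mus musculus) for metabolic stability, read by LC-MS, using microsomes, tested at 1 uM; on this read-out lower numbers stand for a shorter-lived compound and higher numbers for a longer-lived compound:
- Compound 1 (`CCN(CC)CCCN/C(=N\c1ccnc2cc(Cl)ccc12)c1cccnc1`): > 1 h (a limit)
- Compound 2 (`CN(C)CCCN/C(=N\c1ccnc2cc(Cl)ccc12)c1ccccc1`): 0.867 h

The entry for compound 1 is a limit and not a number. Within the data shown here, compound 2 at 0.867 h holds the only actual number. Compound 3 (`CCN(CC)CCCN/C(=N\c1ccnc2cc(Cl)ccc12)c1ccccc1`) has diethylamino in place of dimethylamino on a saturated chain carbon, three bonds along the chain from an amine nitrogen. Among the measured compounds shown here, no measured pair isolates this change. For the measured compounds named here, compound 1 also carries diethylamino but differs elsewhere too, so it gives no size for the step. In this assay the expected 1.1-fold lower number from compound 2 to compound 3 (0.03 log units; within the scatter) stays within the scatter, with no firm direction. Compound 3 is estimated at 0.8 h with an expected range from 0.4 h to 1.2 h for now.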

Compound 3, half-life: 0.267 h
The estimate for compound 3 lay 3.0-fold (0.48 log units) above the measured number; measured number outside the range, below it.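

In this assay, the terminal amine now has a step of measured size: diethylamino in place of dimethylamino on a saturated chain carbon, three bonds along the chain from an amine nitrogen, gives a 3.2-fold lower number from compound 2 to compound 3 (0.51 log units; beyond the scatter). With diethylamino held constant, phenyl in place of pyridin-3-yl on a carbon with a double bond to nitrogen gives an at least 3.7-fold lower number from compound 1 to compound 3 (0.57 log units; beyond the scatter). This second step rests on the entry for compound 1, which is a limit and not a number: the limit of > 1 h in this assay, at which 1 of the 3 values shown sits.

As far as these compounds go, whether pyridin-3-yl gives a similar step alongside dimethylamino remains open. Also open, from the compounds shown here alone, is how a cyclic amine such as pyrrolidine or a longer chain would read here.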